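Swapping an aryl ether for a benzyl ether

This account rests on a few compounds, and the source may have more. Where it says the series, first, only, none or still open, it means among the compounds named here.

Compound 1 `Cc1ccccc1Oc1ccc(CC2SC(=O)NC2=O)cc1` is the better of the two measured compounds in a functional assay for agonist activity at Free fatty acid receptor 1 (Homo sapiens), read by FLIPR, in the presence of a further agent that is not named here (on this read-out lower numbers stand for an effect already at smaller amounts and higher numbers for an effect only at larger amounts of compound), where compound 1 gives 124 nM. Going by the values given here, its only measured neighbour is compound 2 `Cc1cccc(Oc2ccc(CC3SC(=O)NC3=O)cc2)c1C`, which in this assay gives 334 nM; the step of a 2.7-fold higher number from compound 1 to compound 2 (0.43 log units; beyond the scatter) comes from a methyl in place of hydrogen on an aromatic carbon. Compound 3 `O=C1NC(=O)C(Cc2ccc(OCc3ccccc3)cc2)S1` has not been measured. It differs from compound 1 by benzyl in place of 2-methylphenyl on an oxygen on an aromatic ring, so the change is benzyl in place of 2-methylphenyl on an oxygen on an aromatic ring. Among the compounds with values here, the one measured step does not touch this kind of change, so no direct guide exists; the step of a 2.7-fold higher number from compound 1 to compound 2 (0.43 log units; beyond the scatter) shows only that a small addition near the ether already cost a modest amount. For compound 3 a step of a 2.0-fold higher number from compound 1 to compound 3 (0.30 log units; within the scatter) is therefore expected, a modest loss that may still fall within the scatter. Compound 3 is estimated at 250 nM, within 60 nM to 1000 nM.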

Compound 3, half-maximal effective concentration: 6180 nM
Estimate against measurement, compound 3: 25-fold (1.39 log units) below, outside the stated range (above it).
By their numbers in this assay, from the lowest: compound 1; then compound 2; then compound 3.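

In this assay, going by these compounds alone, the change on the oxygen gives a 50-fold higher number from compound 1 to compound 3 (1.70 log units; beyond the scatter), so this position is far more sensitive than the single methyl step suggested. The 2-methylphenyl and benzyl groups have the same count of heavy atoms, and each carries one six-membered aromatic ring, so the large loss shows that how the same atoms are joined matters here, not just how many there are. No measured evidence explains this loss.

Going by these compounds, the swap alters two things at once, removing the methyl from the aromatic ring and placing a carbon between that ring and the oxygen, so the share of each in the loss remains open. A plain phenyl group on the same oxygen would help separate the two, and a longer chain such as 2-phenylethyl would show how the number changes as the ring moves further from the oxygen.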